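Carbonyl substituents: from compound 3 to compound 4

This account rests on a few compounds, and the source may have more. Where it says the series, first, only, none or still open, it means among the compounds named here.

Measured values:
- compound 1 `O=C(O)C1(S(=O)(=O)c2ccc(Oc3ccc(OC(F)(F)F)cc3)cc2)CCC2(CCNCC2)C1`: 1800 nM
- compound 2 `O=C(OCc1ccccc1)C1(S(=O)(=O)c2ccc(Oc3ccc(OC(F)(F)F)cc3)cc2)CCC2(CCNCC2)C1`: > 15000 nM
- compound 3 `O=C(Oc1ccccc1)C1(S(=O)(=O)c2ccc(Oc3ccc(OC(F)(F)F)cc3)cc2)CCC2(CCNCC2)C1`: 900 nM

All values come from a functional assay on blood (Homo sapiens), with a stated time of 60 min, in the presence of a further agent that is not named here; a lower number here means that less compound is needed, a higher number that more compound is needed for the effect. The entry for compound 2, > 15000 nM, is a limit of the assay. For the measured compounds named here, compound 3 stands within the scatter of the only other numerical value, with a 2.0-fold lower number from compound 1 to compound 3 (0.30 log units; within the scatter).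

Compound 4 `O=C(Nc1nccs1)C1(S(=O)(=O)c2ccc(Oc3ccc(OC(F)(F)F)cc3)cc2)CCC2(CCNCC2)C1` is reached by the change ((1,3-thiazol-2-yl)amino in place of phenoxy on a carbonyl carbon), which reads phenoxycarbonyl to (1,3-thiazol-2-yl)carbamoyl. Going by the values given here, no measured step makes this exchange, and none introduces a (1,3-thiazol-2-yl)amino group. The nearest evidence comes from other changes on the carbonyl group. These range from a 2.0-fold lower number from compound 1 to compound 3 (0.30 log units; within the scatter) to an at least 8.3-fold higher number from compound 1 to compound 2 (0.92 log units; beyond the scatter), and the two esters differ by an at least 16-fold lower number from compound 2 to compound 3 (1.22 log units; beyond the scatter). Among the compounds with values here, the series is therefore sensitive at this place, though on only three compounds. The expectation leans upward on the precedent of compound 2, with an at least 8.3-fold higher number from compound 1 to compound 2 (0.92 log units; beyond the scatter), and a modest rise beyond the scatter is expected. The expected step is a 4.4-fold higher number from compound 3 to compound 4 (0.65 log units; beyond the scatter). For compound 4 the estimate is 4000 nM, with an expected range of 700 nM to 15000 nM.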

Compound 4, half-maximal effective concentration: > 15000 nM
Compound 4: only a limit was reported; the forecaster's own chance of this, stated with the estimate: 35%; middle value at least 3.7-fold (0.57 log units) from the limit.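

In this assay, compound 4 gives > 15000 nM, which is a limit of the assay. Replacing phenoxy with (1,3-thiazol-2-yl)amino on this carbonyl carbon gives an at least 16-fold higher number from compound 3 to compound 4 (1.22 log units; beyond the scatter), and replacing hydroxy with the same group gives an at least 8.3-fold higher number from compound 1 to compound 4 (0.92 log units; beyond the scatter), so an aromatic ring carried on the carbonyl does not by itself hold the number down. The amide now sits with the benzyl ester, compound 2, at the same limit: the limit of > 15000 nM in this assay, at which 2 of the 4 values shown sit.

Compound 2 and compound 4 are both limits, and the step between them cannot be read. Going by these compounds, it remains open whether the rise follows the thiazole ring or the amide link itself; a phenylamino group or a plain unsubstituted amide on the same carbonyl would separate the two.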